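The source may report more compounds than this note shows. Statements on the series, on what has been measured and on what is new or still open speak of the compounds shown alone.

Measured compounds in a functional assay on RXF 393 cells (Homo sapiens) for inhibition, read by sulforhodamine B assay, with a stated time of 48 h; a higher number here means a weaker inhibitor of growth, a lower number a stronger inhibitor of growth:
compound 1 `O=C(Nc1cccc(-n2cc(-c3ccncc3)c(-c3ccc(Cl)c(O)c3)n2)c1)Nc1cccc(C(F)(F)F)c1` gives 3020 nM
compound 2 `O=C(Nc1cccc(-n2cc(-c3ccncc3)c(-c3ccc(Cl)c(O)c3)n2)c1)Nc1ccc(Cl)c(Cl)c1` gives 1000 nM
compound 3 `COc1cc(-c2nn(-c3cccc(NC(=O)c4ccc(Cl)c(C(F)(F)F)c4)c3)cc2-c2ccncc2)ccc1Cl` gives 1760 nM

Among these three, compound 1 carries the highest number in this assay. Its gap to compound 3 is within the usual scatter, so the two cannot be ordered; its gap to compound 2 is larger, a 3.0-fold lower number from compound 1 to compound 2 (0.48 log units; beyond the scatter), a step that arises from 3,4-dichlorophenyl in place of 3-(trifluoromethyl)phenyl on an amide-type nitrogen.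

Compound 4 `O=C(Nc1cccc(-n2cc(-c3ccncc3)c(-c3ccc(Cl)c(O)c3)n2)c1)Nc1cc(C(F)(F)F)cc(C(F)(F)F)c1` has not yet been measured. It differs from compound 1 in one place: trifluoromethyl in place of hydrogen on an aromatic carbon. Among the compounds with values here, only one measured step changes the same aryl ring of the shared core, the move from compound 1 to compound 2, and it was modest in size and went toward a lower number. That step also replaces the trifluoromethyl rather than adding one, so it is only a partial guide. A step of similar or smaller size toward a lower number, or none beyond the scatter, is therefore the expectation for this assay.

Compound 4 is accordingly expected to give about 2000 nM, with a plausible range from 700 nM to 6000 nM. This estimate means a step of a 1.5-fold lower number from compound 1 to compound 4 (0.18 log units; within the scatter), which is expected to stay close to the scatter.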

Compound 4, concentration for 50% growth inhibition: 937 nM
Beside the measured number, compound 4's estimate is 2.1-fold (0.33 log units) above it; the measured number falls inside the stated range.
By their numbers in this assay, from the lowest: compounds 4, 2, 3 and 1 (each within the scatter of the next, the first and the last beyond it).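

In this assay, a trifluoromethyl entering on an aromatic carbon meta to a trifluoromethyl group gives a 3.2-fold lower number from compound 1 to compound 4 (0.51 log units; beyond the scatter), so this position of the ring takes an added group of this size with a lower number, not a higher one. The earlier step on the same ring, a 3.0-fold lower number from compound 1 to compound 2 (0.48 log units; beyond the scatter), replaced the trifluoromethyl of compound 1, and it could not show what happens when that group stays and a second one joins it; compound 4 shows that the number can also fall with the first trifluoromethyl kept in place. Nothing available bears on why the number falls with this change.

Going by these compounds, whether a methyl, an amine or a carboxylic acid on this same aromatic carbon would move the number in the same direction as trifluoromethyl remains open. Also open is whether the step from compound 1 to compound 4 would carry over to other cell lines, since the compounds shown are compared in this single growth assay alone.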